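Working notes: the step from compound 1 to compound 4

This account rests on a few compounds, and the source may have more. Where it says the series, first, only, none or still open, it means among the compounds named here.

In a functional assay on VCaP cells (Homo sapiens) for antiproliferative activity, read by CCK-8 assay, with a stated time of 6 days (on this read-out higher numbers stand for weaker inhibition and lower numbers for stronger inhibition), compound 1 (`CC(=O)c1cc(C(=O)N[C@@H](C)Cn2ccc(-c3cc(F)c(C#N)c(Cl)c3)n2)n[nH]1`) has no number, its entry reading "not determined" (no result reported). Compound 2 (`CC(=O)c1cc(C(=O)N[C@H](C)Cn2ccc(-c3cc(F)c(C#N)c(Cl)c3)n2)n[nH]1`) fares no better, at "not determined" (no result reported). Going by the values given here, the only relation between this pair is the fact that compounds 1 and 2 differ only in the configuration as drawn, and it offers no measured guide. Among the compounds with values here, the sole number belongs to compound 3 (`C[C@@H](Cn1ccc(-c2ccc(C#N)c(Cl)c2)n1)NC(=O)C1CC(=O)C1`), at 22500 nM.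

The change under review is (5-(tert-butyl)-1H-pyrazol-3-yl)amino in place of 5-acetyl-1H-pyrazol-3-yl on a carbonyl carbon, which gives compound 4 (`C[C@@H](Cn1ccc(-c2cc(F)c(C#N)c(Cl)c2)n1)NC(=O)Nc1cc(C(C)(C)C)[nH]n1`). In counted terms: (5-(tert-butyl)-1H-pyrazol-3-yl)amino in place of 5-acetyl-1H-pyrazol-3-yl on a carbonyl carbon.

With no number for compound 1, the size of this step in this assay cannot be read from the data. Within the data shown here, the only anchor is compound 3 at 22500 nM, and compound 4 is expected to sit well on the side of stronger inhibition relative to that value, with wide uncertainty. For compound 4 the estimated value is 3000 nM, with an expected range of 300 nM to 25000 nM.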

Compound 4, half-maximal inhibitory concentration: 5120 nM
Estimate against measurement, compound 4: 1.7-fold (0.23 log units) below; the range from low to high includes it.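

Going by these compounds alone, compound 4 at 5120 nM yields no new step: compound 1 has no number, and compound 3 differs from compound 4 in more than one place. The compounds shown leave open what the group exchange on the carbonyl carbon alone does to antiproliferative activity. Nothing available bears on this result.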